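From formyl to (1-hydroxyethyl)carbonyl: compound 3

This account rests on a few compounds, and the source may have more. Where it says the series, first, only, none or still open, it means among the compounds named here.

Going by the values given here, in an in vivo ADME assay on the whole organism (strain Swiss) for pharmacokinetics, with Mus musculus as the target, read by LC-MS, at a dose of 10 mg/kg by the oral route (a higher number here means that a larger share of the oral dose reaches the circulation, a lower number that a smaller share of the oral dose reaches the circulation), compound 1 `Nc1ncnc2c1nc(Sc1cc3c(cc1Br)OCCO3)n2CCC1CCN(C=O)CC1` gives 30% and compound 2 `C[C@H](O)C(=O)N1CCC(CCn2c(Sc3cc4c(cc3Br)OCCO4)nc3c(N)ncnc32)CC1` gives 20% as values within the scatter of each other, so compound 1 stands level with the only other measured compound. Compound 3 `C[C@@H](O)C(=O)N1CCC(CCn2c(Sc3cc4c(cc3Br)OCCO4)nc3c(N)ncnc32)CC1` differs from compound 1 by 1-hydroxyethyl in place of hydrogen on a carbonyl carbon and the change reads formyl to (1-hydroxyethyl)carbonyl. Among the compounds with values here, one measured step bears on it, the same change in words, a number 10 percentage points lower from compound 1 to compound 2 (within the scatter) and no other is available. No step beyond the scatter is therefore expected. The expected step is a number 8 percentage points lower from compound 1 to compound 3 (within the scatter) and stays within the scatter. For compound 3 the estimated value is 22% (expected range 10% to 35%).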

Compound 3, oral bioavailability: 32%
For compound 3 the middle estimate is 10 percentage points below the measured one, and the stated range covers the measured number.
By their numbers in this assay, from the lowest: compounds 2, 1 and 3 (each within the scatter of the next, the first and the last beyond it).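

In this assay, the configuration at the 1-hydroxyethyl carbon now matters, with a number 12 percentage points higher from compound 2 to compound 3 (beyond the scatter). This step can be assigned to configuration alone because of one fact: the fact that compounds 2 and 3 differ only in the configuration as drawn

With the stereocentre drawn R, placing 1-hydroxyethyl on the carbonyl carbon gives a number 2 percentage points higher from compound 1 to compound 3 (within the scatter).

Still open, as far as these compounds go, is how an amine or a longer chain on this carbonyl carbon would read in this assay. Also open, from the compounds shown here alone, is whether a configuration step appears with any group other than 1-hydroxyethyl, as a single pair of compounds carries it here.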